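Solubility notes: aryl to isobutyl swap on the shared core

The source may report more compounds than this note shows. Statements on the series, on what has been measured and on what is new or still open speak of the compounds shown alone.

Compound 1 `COc1cccc(CNCCCNc2ccnc3cc(-c4ccc(F)cc4)ccc23)c1O` and compound 2 `COc1cccc(CNCCCNc2ccnc3cc(-c4cccc5ccccc45)ccc23)c1O` share one core and differ only at one aromatic carbon. In a physicochemical assay for solubility, with a stated time of 18 h, at pH 7.4 (on this read-out higher numbers stand for higher solubility and lower numbers for lower solubility), compound 1 gives 32000 nM, and in this assay compound 2 gives 32000 nM. The step of no change at the digits printed from compound 1 to compound 2 (within the scatter) thus places compound 2 level with compound 1 at the digits shown, and no other measured compound sits near it.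

Compound 3 `COc1cccc(CNCCCNc2ccnc3cc(CC(C)C)ccc23)c1O` is the next member. The change from compound 2 is isobutyl in place of naphthalen-1-yl on an aromatic carbon. Within the data shown here, only one measured step exists, and it exchanged one aromatic group for another; no measured pair exchanges an aromatic group for an alkyl chain, so nothing on record tests a change of this kind. Among the measured compounds shown here, the single step of no change at the digits printed from compound 1 to compound 2 (within the scatter) sets the only available reference and shows no movement beyond the scatter.

On that basis, compound 3 is expected in this assay to stay close to compound 2, with the step of a 1.3-fold higher number from compound 2 to compound 3 (0.10 log units; within the scatter) taken as the estimate. For compound 3 the estimate is 40000 nM, within a range from 16000 nM to 100000 nM.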

Compound 3, solubility: 4200 nM
Beside the measured number, compound 3's estimate is 9.5-fold (0.98 log units) above it; measured number outside the range, below it.
By their numbers in this assay, from the lowest: compound 3; then compounds 1 and 2 (each within the scatter of the next).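

In this assay, this aromatic carbon of the shared core proves sensitive to the kind of group it carries: the earlier exchange of one aromatic group for another gave no separation, whereas isobutyl gives a 7.6-fold lower number from compound 2 to compound 3 (0.88 log units; beyond the scatter) and likewise a 7.6-fold lower number from compound 1 to compound 3 (0.88 log units; beyond the scatter). Both steps lie beyond the scatter and are modest, so naphthalen-1-yl and 4-fluorophenyl remain level despite their different ring counts, while isobutyl, with no ring, stands lowest among these three compounds and no compound here goes against that order. No supporting data bear on the origin of this drop.

From the compounds shown here alone, whether the drop is specific to isobutyl or extends to alkyl groups in general remains open, and ethyl, n-hexyl and cyclohexyl at this carbon would help separate the presence of a ring from the presence of a chain. Going by these compounds, how an amine or a carboxylic acid at the same aromatic carbon would read in this assay also remains open, as does whether a small aromatic group such as unsubstituted phenyl stays level with compound 1.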